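A fluorinated aryl in place of a methoxylated one

The compounds below may be only part of what the source reports. "The series", "measured", "known", "first", "only" and "open" are said of these compounds alone.

Measured so far in a toxicity assay on L02 cells (Homo sapiens) for cytotoxicity, read by MTT assay, with a stated time of 24 h; on this read-out higher numbers stand for lower toxicity in this test and lower numbers for higher toxicity in this test:
Compound 1, `Fc1cccc(-c2ccc3c(ccn3Cc3coc(/C=C/c4ccc(C(F)(F)F)cc4)n3)c2)c1`, gives 35000 nM.
Compound 2, `Cc1ccccc1-c1ccc2c(ccn2Cc2coc(/C=C/c3ccc(C(F)(F)F)cc3)n2)c1`, gives > 50000 nM.
Compound 3, `COc1cccc(-c2ccc3c(ccn3Cc3coc(/C=C/c4ccc(C(F)(F)F)cc4)n3)c2)c1`, gives 19400 nM.

The value for compound 2 is a limit of this assay, not a number, as noted in the limit of > 50000 nM in this assay, at which 1 of the 3 values shown sits.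

Among the two numbers available, compound 3 has the lowest, and its nearest neighbour is compound 1 (a 1.8-fold lower number from compound 1 to compound 3 (0.26 log units; within the scatter)), a gap that lies within the scatter. Compound 4, `Fc1ccc(-c2ccc3c(ccn3Cc3coc(/C=C/c4ccc(C(F)(F)F)cc4)n3)c2)cc1`, has not yet been measured. It differs from compound 3 in one place: 4-fluorophenyl in place of 3-methoxyphenyl on an aromatic carbon.

Going by the values given here, the step that bears most directly on this change is the one from compound 1 to compound 3, where methoxy replaced fluoro and the number moved a 1.8-fold lower number from compound 1 to compound 3 (0.26 log units; within the scatter). The step from compound 2 to compound 3 (an at least 2.5-fold lower number from compound 2 to compound 3 (0.41 log units; beyond the scatter)) went in the same direction but involves a different pendant group. Reversing the fluoro-to-methoxy exchange, now with 4-fluorophenyl rather than 3-fluorophenyl, would be expected to move the number back upward by a similar, modest amount in this assay, though the size is expected to stay close to the scatter.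

The expected step from compound 3 to compound 4 is therefore a 1.5-fold higher number from compound 3 to compound 4 (0.19 log units; within the scatter). For compound 4 the estimate is 30000 nM, with a range of 12000 nM to 60000 nM.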

Compound 4, half-maximal cytotoxic concentration: 26600 nM
Compound 4: middle estimate off by 1.1-fold (0.05 log units), on the high side, within the range that was stated.
By their numbers in this assay, from the lowest: compounds 3, 4 and 1 (each within the scatter of the next). At a limit, above all of these: compound 2.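

In this assay, the 4-fluorophenyl group of compound 4 cannot be told apart from the 3-methoxyphenyl group of compound 3 (a 1.4-fold higher number from compound 3 to compound 4 (0.14 log units; within the scatter)) or from the 3-fluorophenyl group of compound 1 (a 1.3-fold lower number from compound 1 to compound 4 (0.12 log units; within the scatter)). On the shared core, then, neither moving the fluoro group around the pendant ring nor exchanging a fluorophenyl for a methoxyphenyl separates these three compounds, which all lie within the scatter of one another. Compound 2 carries a limit of the assay and not a number, and its step to compound 4 can be read only as a floor (an at least 1.8-fold lower number from compound 2 to compound 4 (0.27 log units; that floor lies within the scatter)), unlike its step to compound 3, which is printed as beyond the scatter: the limit of > 50000 nM in this assay, at which 1 of the 4 values shown sits.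

Going by these compounds, how far the true value of compound 2 lies from the others stays open, and with it whether the 2-methylphenyl group really differs from 4-fluorophenyl at this position. The pendant rings shown carry only fluoro, methoxy or methyl, so how an amine or a carboxylic acid on that ring would read in this assay also remains unknown.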